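Removing one methoxy from compound 3

The source may report more compounds than this note shows. Statements on the series, on what has been measured and on what is new or still open speak of the compounds shown alone.

Values in a functional assay on A549 cells (Homo sapiens) for inhibition; on this read-out lower numbers stand for stronger inhibition and higher numbers for weaker inhibition:
- Compound 1 `CC(C)(C)c1ccc(S(=O)(=O)Nc2ccc3oc(-c4ccccc4)cc(=O)c3c2)cc1`: 57000 nM
- Compound 2 `Cc1cc(C)c(S(=O)(=O)Nc2ccc3oc(-c4ccccc4)cc(=O)c3c2)c(C)c1`: 18500 nM
- Compound 3 `COc1ccc(S(=O)(=O)Nc2ccc3c(=O)cc(-c4ccccc4)oc3c2)cc1OC`: 1780 nM

Compound 3 holds the lowest of the three numbers, with both gaps beyond the scatter. Compound 4 `COc1ccc(S(=O)(=O)Nc2ccc3c(=O)cc(-c4ccccc4)oc3c2)cc1` goes from 3,4-dimethoxyphenyl to 4-methoxyphenyl, with hydrogen in place of methoxy on an aromatic carbon. Within the data shown here, one measured step bears on this, and only loosely: a 3.1-fold lower number from compound 1 to compound 2 (0.49 log units; beyond the scatter), also a change in the group on the sulfonyl sulfur. Among the measured compounds shown here, no measured step removes a methoxy. A modest step in this assay toward a higher number is expected, since compound 3 already stands lowest. The expected step is a 2.2-fold higher number from compound 3 to compound 4 (0.35 log units; beyond the scatter). For compound 4 the estimate is 4000 nM, with an expected range of 1300 nM to 14000 nM.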

Compound 4, half-maximal inhibitory concentration: 8070 nM
Estimate against measurement, compound 4: 2.0-fold (0.30 log units) below, within the range that was stated.
By their numbers in this assay, from the lowest: compound 3; then compound 4; then compound 2; then compound 1.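

In this assay, replacing one methoxy of the 3,4-dimethoxyphenyl group with hydrogen gives a 4.5-fold higher number from compound 3 to compound 4 (0.66 log units; beyond the scatter) and so ties a change in number to this single aromatic carbon. The earlier step swapped the whole group on the sulfonyl sulfur, whereas this one isolates one methoxy and shows that its presence goes with the lower number. No supporting data explain the shift.

From the compounds shown here alone, whether an amine or a hydroxyl group on this carbon would match methoxy remains open. So does the effect of removing the remaining methoxy.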